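Fluoro in Place of Methyl on the Phenyl Ring

The source may report more compounds than this note shows. Statements on the series, on what has been measured and on what is new or still open speak of the compounds shown alone.

Compound 1 `CC1CCc2sc(NC(=O)CN3CCN(c4ccc(F)cc4)CC3)nc2C1`: 5100 nM
Compound 2 `O=C(CN1CCN(c2ccc(F)cn2)CC1)Nc1nc2c(s1)CCCC2`: 600 nM
Compound 3 `Cc1ccc(N2CCN(CC(=O)Nc3nc4c(s3)CCCC4)CC2)cc1`: > 10000 nM

In an assay on isolated protein for inhibition of long-chain fatty acid transport protein 1 (Mus musculus), read by scintillation counting, with a stated time of 20 min (a lower number here means a stronger inhibitor, a higher number a weaker inhibitor), compound 2 gives 600 nM. Compound 3 stands at a limit of this assay, > 10000 nM, which is not a number. That limit is described by the limit of > 10000 nM in this assay, at which 1 of the 3 values shown sits. Among the measured compounds shown here, the one measured step that touches the group on the ring amine nitrogen is an at least 16-fold higher number from compound 2 to compound 3 (1.22 log units; beyond the scatter), a large loss. Compound 4 `O=C(CN1CCN(c2ccc(F)cc2)CC1)Nc1nc2c(s1)CCCC2` differs from compound 3 by fluoro in place of methyl on an aromatic carbon. For the measured compounds named here, no measured step covers this exact exchange; compound 1 carries the same 4-fluorophenyl together with a methyl on the shared core and gives 5100 nM. A gain beyond the scatter is expected, an at least 3.3-fold lower number from compound 3 to compound 4 (0.52 log units; beyond the scatter). Compound 4 is expected at 3000 nM, in the range 1000 nM to 10000 nM.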

Compound 4, half-maximal inhibitory concentration: 4000 nM
Estimate against measurement, compound 4: 1.3-fold (0.12 log units) below; low and high end bracket the measured number.
By their numbers in this assay, from the lowest: compound 2; then compounds 4 and 1 (each within the scatter of the next). At a limit, above all of these: compound 3.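

Fluoro at this place on the phenyl ring brings a gain over methyl, an at least 2.5-fold lower number from compound 3 to compound 4 (0.39 log units; beyond the scatter). Compound 3 stands at a limit, so this gain has no fixed size: the limit of > 10000 nM in this assay, at which 1 of the 4 values shown sits. The 4-fluorophenyl still falls short of the 5-fluoropyridin-2-yl, a 6.7-fold higher number from compound 2 to compound 4 (0.82 log units; beyond the scatter), while the methyl on the saturated ring carbon of the shared core changes nothing beyond the scatter, a 1.3-fold lower number from compound 1 to compound 4 (0.11 log units; within the scatter).

Open, as far as these compounds go, is how chloro or methoxy would fare at this same place on the phenyl ring. Also open, from the compounds shown here alone, is whether methyl on the pyridine ring, as 5-methylpyridin-2-yl, would cost as much as it does on phenyl.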